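Amino for nitro on a pyridyl ether scaffold

The compounds below may be only part of what the source reports. "The series", "measured", "known", "first", "only" and "open" are said of these compounds alone.

Compound 1: `CN1CCC[C@H]1COc1cncc(C(F)(F)F)c1`, 1.83 nM
Compound 2: `CCc1cncc(OC[C@@H]2CCCN2C)c1`, 0.32 nM
Compound 3: `CN1CCC[C@H]1COc1cncc([N+](=O)[O-])c1`, 4.65 nM

In an assay on membranes from brain for displacement of a labelled ligand from Neuronal acetylcholine receptor; alpha4/beta2 (Rattus norvegicus) (on this read-out lower numbers stand for stronger inhibition and higher numbers for weaker inhibition), compound 3 has the highest number of the three. Its nearest neighbour is compound 1, with the step of a 2.5-fold higher number from compound 1 to compound 3 (0.41 log units; beyond the scatter), and the widest gap is to compound 2, with the step of a 15-fold higher number from compound 2 to compound 3 (1.16 log units; beyond the scatter). Compound 4, `CN1CCC[C@H]1COc1cncc(N)c1`, has not yet been measured. It differs from compound 3 in one place: amino in place of nitro on an aromatic carbon.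

For the measured compounds named here, no measured step exchanges an amino group for anything, so the guide is indirect. The three steps that exist all concern the same position on the shared core and show that the choice of substituent there moves the number substantially: a 5.7-fold lower number from compound 1 to compound 2 (0.76 log units; beyond the scatter), a 2.5-fold higher number from compound 1 to compound 3 (0.41 log units; beyond the scatter) and a 15-fold higher number from compound 2 to compound 3 (1.16 log units; beyond the scatter). The nitro group of compound 3 sits at the weak end of this short series, so replacing it is more likely to lower the number than to raise it further, though the size of the effect remains uncertain.

Compound 4 is therefore expected to give a modest improvement, a 2.3-fold lower number from compound 3 to compound 4 (0.37 log units; beyond the scatter), in this assay. The estimated value for compound 4 is 2 nM, with a range from 0.5 nM to 8 nM.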

Compound 4, inhibition constant: 0.63 nM
Compound 4: middle estimate off by 3.2-fold (0.50 log units), on the high side; the range from low to high includes it.
By their numbers in this assay, from the lowest: compounds 2 and 4 (each within the scatter of the next); then compound 1; then compound 3.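

Exchanging nitro for amino in this assay (a 7.4-fold lower number from compound 3 to compound 4 (0.87 log units; beyond the scatter)) shows that this position holds a second group at the low end of the numbers, and that the nitrogen-bearing nitro of compound 3 says little about what a nitrogen-bearing group can do here. For the compounds shown here, compound 4 also gives a lower number than the trifluoromethyl compound (a 2.9-fold lower number from compound 1 to compound 4 (0.46 log units; beyond the scatter)), while it cannot be told apart from the ethyl compound (a 2.0-fold higher number from compound 2 to compound 4 (0.29 log units; within the scatter)), so two groups as different as ethyl and amino, the latter counting a hydrogen-bond donor, now share that low end, and the earlier compounds, in which only ethyl stood there, could not show this. Nothing in the data shown accounts for this outcome.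

Going by these compounds, what the hydrogens of the amino group contribute stays open, and a methylamino or dimethylamino group in the same place would bear on that question. Equally open, on these data alone, is whether a hydroxyl or methoxy group, or a longer chain such as propyl, would join compounds 2 and 4 or fall back towards compound 3.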